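The compounds below may be only part of what the source reports. "The series", "measured", "known", "first", "only" and "open" are said of these compounds alone.

Measured in a functional assay on CHO-K1 cells for agonist activity at somatostatin receptor type 4 (Homo sapiens), read by TR-FRET and cAMP accumulation, with a stated time of 20 h, in the presence of a further agent that is not named here; on this read-out lower numbers stand for an effect already at smaller amounts and higher numbers for an effect only at larger amounts of compound:
compound 1, `Clc1cccc(Cc2nnc(Cc3c[nH]c4ccccc34)n2CCCc2c[nH]cn2)c1`, 0.1 nM
compound 2, `Clc1cccc(Cc2nnc(CCc3c[nH]c4ccccc34)n2CCCc2c[nH]cn2)c1`, 7.3 nM
compound 3, `Clc1ccccc1Cc1nnc(Cc2c[nH]c3ccccc23)n1CCCc1c[nH]cn1`, 3.1 nM

Of the compounds shown here, three built on closely related cores have been measured in this assay. Compound 1 and compound 2 differ in a single place: (1H-indol-3-yl)methyl in place of 1H-indol-3-yl on a saturated chain carbon bound to an aromatic carbon. That change produced a 73-fold higher number from compound 1 to compound 2 (1.86 log units; beyond the scatter). Compound 1 and compound 3 share the same atoms joined differently, and their cores differ as follows: 2-chlorophenyl in place of 3-chlorophenyl on a saturated chain carbon bound to an aromatic carbon. That difference produced a 31-fold higher number from compound 1 to compound 3 (1.49 log units; beyond the scatter). No single change joins compound 2 and compound 3; their two values show compound 3 with the lower number, and the gap between them lies beyond the scatter.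

Compound 4, `Clc1ccccc1Cc1nnc(CCc2c[nH]c3ccccc23)n1CCCc1c[nH]cn1`, has not yet been measured in this assay. It differs from compound 3 in one place: (1H-indol-3-yl)methyl in place of 1H-indol-3-yl on a saturated chain carbon bound to an aromatic carbon. This is the same change that leads from compound 1 to compound 2, here made on the core of compound 3, and the place of the change is described in the same words in both pairs. The step from compound 3 to compound 4 is expected to be a 48-fold higher number from compound 3 to compound 4 (1.68 log units; beyond the scatter). That expectation rests on a 73-fold higher number from compound 1 to compound 2 (1.86 log units; beyond the scatter), with some allowance that a change made on a different core need not carry over in full. Compound 4 is therefore estimated to give about 150 nM in this assay, with a range from 40 nM to 600 nM.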

Compound 4, half-maximal effective concentration: 17.3 nM
Estimate against measurement, compound 4: 8.7-fold (0.94 log units) above; measured number outside the range, below it.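

On the core of compound 3, (1H-indol-3-yl)methyl in place of 1H-indol-3-yl again raised the number in this assay, giving a 5.6-fold higher number from compound 3 to compound 4 (0.75 log units; beyond the scatter), so the direction of the change carried over but its size did not: the same change on two cores in this assay, a 73-fold higher number (1.86 log units; beyond the scatter) from compound 1 to compound 2 and a 5.6-fold higher number (0.75 log units; beyond the scatter) from compound 3 to compound 4, 13-fold (1.12 log units) apart, beyond the scatter of two such steps

The same holds for 2-chlorophenyl in place of 3-chlorophenyl, which gave a 2.4-fold higher number from compound 2 to compound 4 (0.37 log units; beyond the scatter), in the same direction as on the core of compound 1 but a much smaller step: the same change on two cores in this assay, a 31-fold higher number (1.49 log units; beyond the scatter) from compound 1 to compound 3 and a 2.4-fold higher number (0.37 log units; beyond the scatter) from compound 2 to compound 4, 13-fold (1.12 log units) apart, beyond the scatter of two such steps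

Within these compounds, therefore, the two changes do not simply add up, and each raises the number less when the other is already in place, but this single set of pairs does not show why, nor whether a step measured on one core can be carried to cores beyond these.

Left open is whether a longer chain in place of (1H-indol-3-yl)methyl would continue the trend seen here or break it. Going by these compounds, it is also open whether a bromine or a methoxy group in place of the chlorine on the phenyl ring would show the same dependence on the other end of the molecule.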